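Difluorophenyl ketone in place of aminophenyl in compound 1

The compounds below may be only part of what the source reports. "The series", "measured", "known", "first", "only" and "open" are said of these compounds alone.

Measured so far in a functional assay on U-251 cells (Homo sapiens) for cytotoxicity, read by sulforhodamine B assay, with a stated time of 48 h, tested at 1 uM; a lower number here means a stronger effect, a higher number a weaker effect of the compound at the concentration tested:
- compound 1, `COc1cc(-c2cc(/C=C/C(=O)c3ccc(N)cc3)[nH]n2)cc(OC)c1OC`, compound 1 gives 76%
- compound 2, `COc1ccc(-c2cc(/C=C/C(=O)c3ccc(N)cc3)[nH]n2)cc1OC`, compound 2 gives 88%
- compound 3, `COc1ccc(-c2cc(/C=C/C(=O)c3cc(OC)c(OC)c(OC)c3)[nH]n2)cc1OC`, compound 3 gives 65%

Compound 1 stands second highest of the three numbers: compound 3 is lower, compound 2 higher, the latter by a number 12 percentage points higher from compound 1 to compound 2 (beyond the scatter) on the aromatic ring bearing the methoxy groups, not on the ketone side.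

Compound 4, `COc1cc(-c2cc(/C=C/C(=O)c3ccc(F)c(F)c3)[nH]n2)cc(OC)c1OC`, differs from compound 1 in 3,4-difluorophenyl in place of 4-aminophenyl on a carbonyl carbon. Among the measured compounds shown here, no measured step covers an exchange at this carbonyl carbon; compound 2 and compound 3 differ there, but on another core, and only their two values are known. Guidance is therefore thin, and compound 4 is expected to move by about a number 6 percentage points lower from compound 1 to compound 4 (within the scatter) in this assay, within or barely beyond the scatter. Compound 4 is estimated at 70%, range 50% to 90%.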

Compound 4, a percentage reported as activity, at one concentration (the size of the read-out at that concentration, not a potency): 87%
Compound 4: the middle estimate sits 17 percentage points below what was measured; measured number inside the range.
By their numbers in this assay, from the lowest: compound 3; then compound 1; then compounds 4 and 2 (each within the scatter of the next).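

In this assay the ketone side proves to matter on the core of compound 1: 3,4-difluorophenyl in place of 4-aminophenyl on the carbonyl carbon gives a number 11 percentage points higher from compound 1 to compound 4 (beyond the scatter), a weaker effect at the concentration tested. Among the compounds shown here, this is the first single-place step read at this carbonyl carbon, and the exchange also loses the hydrogen-bond donor counted on 4-aminophenyl. Nothing available explains the step.

As far as these compounds go, whether the step follows from losing the amine or from gaining the fluorines stays open; a plain phenyl or a monofluorophenyl on the carbonyl carbon would separate the two. From the compounds shown here alone, whether the same exchange behaves alike on the core of compound 2 also stays open.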